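Replacing the carboxypyridinyl group with a trifluoromethyl ketone

This account rests on a few compounds, and the source may have more. Where it says the series, first, only, none or still open, it means among the compounds named here.

Measured compounds:
Compound 1 `O=C(CCCCCCc1ccccc1)c1ncc(-c2ccccc2F)o1` gives 110 nM in an assay (Rattus norvegicus) for inhibition of Fatty-acid amide hydrolase 1 (Homo sapiens); a lower number here means a stronger inhibitor, a higher number a weaker inhibitor.
Compound 2 `O=C(CCCCCCc1ccccc1)c1ncc(-c2ccc(F)cc2)o1` gives 62 nM in this assay.
For compound 3 `O=C(CCCCCCc1ccccc1)c1ncc(-c2ncccc2C(=O)O)o1` only a limit is reported in this assay, > 50 nM.

Compound 3 therefore has no number of its own; it stands at the limit, (the limit of > 50 nM in this assay, at which 1 of the 3 values shown sits), and its place relative to compound 1 and compound 2 cannot be read. The next compound, compound 4 `O=C(CCCCCCc1ccccc1)c1ncc(C(=O)C(F)(F)F)o1`, keeps the rest of the molecule and changes only the group on the shared core: (trifluoromethyl)carbonyl in place of 3-carboxypyridin-2-yl on an aromatic carbon.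

Two measured steps lead into compound 3, a step that the limit leaves unreadable from compound 1 to compound 3 and a step that the limit leaves unreadable from compound 2 to compound 3, and neither gives a readable size. Within the data shown here, the only readable step at this position is a 1.8-fold lower number from compound 1 to compound 2 (0.25 log units; within the scatter), which swaps one aryl group for another and stays within the scatter. Nothing measured therefore points to a direction for the step into compound 4, and no step beyond the scatter is expected, though the starting limit leaves the size open.

Compound 4 is expected to give about 80 nM in this assay, estimated between 10 nM and 600 nM, which means an expected step that the limit leaves unreadable from compound 3 to compound 4.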

Compound 4, inhibition constant: 4 nM
Compound 4: the middle estimate sits 20-fold (1.30 log units) above what was measured; measured number below the stated range.
By their numbers in this assay, from the lowest: compound 4; then compounds 2 and 1 (each within the scatter of the next).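

In this assay, the group on this aromatic carbon can move the number well beyond the scatter, which the swap between the two fluorophenyl groups did not show: (trifluoromethyl)carbonyl in place of an aryl group gives a 16-fold lower number from compound 2 to compound 4 (1.19 log units; beyond the scatter) and a 28-fold lower number from compound 1 to compound 4 (1.44 log units; beyond the scatter). Compound 3 has only a limit, not a number of its own: the limit of > 50 nM in this assay, at which 1 of the 4 values shown sits. Measured against that limit, the change to the smaller, ring-free group still reads as large, with an at least 12-fold lower number from compound 3 to compound 4 (1.09 log units; beyond the scatter).

Open, from the compounds shown here alone, is whether the carbonyl or the fluorines of the entering group carry this step; an acetyl group or a methyl ester on the same carbon would separate the two. Also open, going by these compounds, is whether the step holds with a shorter or longer chain in place of the phenyl-ended chain.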